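Swapping a sulfonamide for a tolyl group on the shared core

The source may hold more compounds than are shown below. What is called first, only, known or untested is meant among the compounds shown, and "the series" means these compounds.

Measured so far:
- compound 1, `COc1ccccc1-c1cn(C[C@H](O)[C@H]2OC(=O)C(OCc3ccccc3)=C2OCc2ccccc2)nn1`, > 100000 nM
- compound 2, `O=C1O[C@H]([C@@H](O)Cn2cc(CNS(=O)(=O)c3ccc(F)cc3)nn2)C(OCc2ccccc2)=C1OCc1ccccc1`, 22500 nM

Compound 1 reaches only the limit of a functional assay on A549 cells (Homo sapiens) for antiproliferative activity, read by MTT assay, with a stated time of 72 h (a higher number here means a weaker inhibitor, a lower number a stronger inhibitor), so its result is not a number but a boundary. Among the compounds with values here, compound 2 is the only compound here with an actual value, and in this assay compound 2 gives 22500 nM. Within the data shown here, the one measured step, an at least 4.4-fold lower number from compound 1 to compound 2 (0.64 log units; beyond the scatter), shows that replacing the aryl group directly on the shared core with the sulfonamide-bearing side chain brought the number down beyond the scatter; how far it truly fell is unknown, because the limit of > 100000 nM in this assay, at which 1 of the 2 values shown sits, hides the starting point.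

Compound 3, `Cc1ccc(-c2cn(C[C@H](O)[C@H]3OC(=O)C(OCc4ccccc4)=C3OCc3ccccc3)nn2)cc1`, reverses that kind of change: 4-methylphenyl in place of (((4-fluorophenyl)sulfonyl)amino)methyl on an aromatic carbon. Compound 3 therefore carries an aryl group directly on the core, as compound 1 does, though a different one. Among the measured compounds shown here, since the only relevant step, an at least 4.4-fold lower number from compound 1 to compound 2 (0.64 log units; beyond the scatter), rewarded the move away from a directly attached aryl group, the return to one is expected to weaken inhibition, with a fair chance that compound 3 again only reaches the assay limit. Compound 3 is expected to give 80000 nM, in the range 25000 nM to 250000 nM, an expected step of a 3.6-fold higher number from compound 2 to compound 3 (0.55 log units; beyond the scatter).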

Compound 3, half-maximal inhibitory concentration: 8690 nM
Beside the measured number, compound 3's estimate is 9.2-fold (0.96 log units) above it; measured number outside the range, below it.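

At this position, on an aromatic carbon of the five-membered aromatic ring with 3 nitrogen, a directly attached aryl group is not in itself a drawback in this assay: 4-methylphenyl in place of the (((4-fluorophenyl)sulfonyl)amino)methyl side chain gives a 2.6-fold lower number from compound 2 to compound 3 (0.41 log units; beyond the scatter). Which aryl group sits there also counts, as exchanging 2-methoxyphenyl for 4-methylphenyl gives an at least 11-fold lower number from compound 1 to compound 3 (1.06 log units; beyond the scatter), a larger step than the one from the side chain. The true size of that larger step remains unknown because compound 1 gives a limit and not a number: the limit of > 100000 nM in this assay, at which 1 of the 3 values shown sits.

Still open, going by these compounds, is whether this gain follows the methyl group itself or the place of the substituent on the phenyl ring, a question that a 4-methoxyphenyl or a plain phenyl group at this position would help to settle. Equally open, on these data alone, is how a phenyl ring carrying an amine or a carboxylic acid would compare with compound 3, which gives 8690 nM.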